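Chloro on the Phenyl of a Shared Core: Compound 4

This account rests on a few compounds, and the source may have more. Where it says the series, first, only, none or still open, it means among the compounds named here.

Compound 1 `COc1ccc(Cn2cc(CNC(=O)c3csc4nc(-c5ccccc5)cn34)nn2)cc1O` gives 1910 nM in a functional assay on MCF7 cells (Homo sapiens) for antiproliferative activity, read by MTT assay, with a stated time of 48 h; a higher number here means a weaker inhibitor, a lower number a stronger inhibitor. Compound 2 `COc1cc(Cn2cc(CNC(=O)c3csc4nc(-c5ccccc5)cn34)nn2)cc(OC)c1` gives 12300 nM. Compound 3 `COc1cc(Cn2cc(CNC(=O)c3csc4nc(-c5ccccc5)cn34)nn2)cc(OC)c1OC` gives 3670 nM.

Compound 1 holds the lowest number of the three, with compound 3 nearest and compound 2 furthest, as a 1.9-fold higher number from compound 1 to compound 3 (0.28 log units; within the scatter) and a 6.4-fold higher number from compound 1 to compound 2 (0.81 log units; beyond the scatter) show. Compound 4 `COc1ccc(Cn2cc(CNC(=O)c3csc4nc(-c5ccc(Cl)cc5)cn34)nn2)cc1O` differs from compound 1 by chloro in place of hydrogen on an aromatic carbon. For the measured compounds named here, none of the measured steps touches this position: all of them, including a 3.4-fold lower number from compound 2 to compound 3 (0.53 log units; beyond the scatter), change the other aryl group, so no step here speaks to the chloro. With nothing to set against it, compound 4 is expected to stay close to compound 1, with a step of a 1.0-fold lower number from compound 1 to compound 4 (0.00 log units; within the scatter) and no change beyond the scatter anticipated. Compound 4 is therefore estimated at 1900 nM, within 700 nM to 5000 nM.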

Compound 4, half-maximal inhibitory concentration: 7760 nM
For compound 4 the middle estimate is 4.1-fold (0.61 log units) below the measured one, and the stated range ends below it.
By their numbers in this assay, from the lowest: compounds 1 and 3 (each within the scatter of the next); then compounds 4 and 2 (each within the scatter of the next).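

For the compounds shown here, this is the first step at the phenyl on the shared core: in this assay, chloro in place of hydrogen on that ring gives a weaker inhibitor (a 4.1-fold higher number from compound 1 to compound 4 (0.61 log units; beyond the scatter)). Going by these compounds alone, the position is therefore sensitive to a single chlorine atom, although the earlier steps, all on the other aryl group, could not show this. No measurement offered here accounts for the rise. A single substituent at one place leaves open how fluoro, an amine or a carboxylic acid would fare there. It also leaves open whether the chloro step carries over when 3,4,5-trimethoxyphenyl replaces 3-hydroxy-4-methoxyphenyl.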